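The compounds below may be only part of what the source reports. "The series", "measured", "known", "first", "only" and "open" are said of these compounds alone.

Measured so far in a functional assay on the whole organism with Mus musculus as the target, at a dose of 100 mg/kg by the intraperitoneal route; on this read-out higher numbers stand for more inhibition at the one dose given (going by the name of the read-out) and lower numbers for less inhibition:
- compound 1 `NC(=O)/C=C1\CCc2c(F)cccc21`: 63%
- compound 2 `NC(=O)/C=C1\CCc2c(F)cc(F)cc21`: 67%
- compound 3 `O=C(/C=C1\CCc2c1ccc(F)c2F)NC1CC1`: 100%

Going by the values given here, only one pair of measured compounds differs in a single place: the step of a number 4 percentage points higher from compound 1 to compound 2 (within the scatter), fluoro in place of hydrogen on an aromatic carbon, lies within the scatter. Compound 3 stands highest of the three numbers; its nearest neighbour is compound 2 and its furthest is compound 1, and both gaps are beyond the scatter. Compound 3 differs from the other two in more than one place, so no single-change step can be read from those gaps.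

Compound 4 `O=C(/C=C1\CCc2cc(F)ccc21)NC1CC1` has not been measured. The change from compound 3 is hydrogen in place of fluoro on an aromatic carbon. Among the compounds with values here, the one measured step of the same kind, from compound 1 to compound 2, runs in the opposite direction, at another place on the ring, and stays within the scatter. The expectation is therefore a step of no more than the scatter, with the read-out of compound 3 already at the top of its range leaving room only downward; the expected step is a number 12 percentage points lower from compound 3 to compound 4 (beyond the scatter). Compound 4 is estimated at 88% in this assay, with a range from 65% to 100%.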

Compound 4, a percentage reported as inhibition, in the whole organism at one dose (the size of the read-out at that dose, not a potency): 100%
Compound 4: middle estimate off by 12 percentage points, on the low side; the range from low to high includes it.
By their numbers in this assay, from the lowest: compounds 1 and 2 (each within the scatter of the next); then compounds 3 and 4 (each within the scatter of the next).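

In this assay, hydrogen in place of the fluoro ortho to a second fluoro group gives no change at the digits printed from compound 3 to compound 4 (within the scatter), so on the core of compound 3 this aromatic carbon does not need fluoro for the read-out to stay at the top of its range. Going by these compounds alone, this is the first single-change step on that core, and it shows that one fluoro fewer leaves the inhibition at this dose unchanged, although both compounds stand at the top of the scale, where any loss that the dose hides cannot be seen. The same change has now been read on two cores, at different places on the aromatic ring, and neither step shows a difference beyond the scatter: the same change on two cores in this assay, a number 4 percentage points higher (within the scatter) from compound 1 to compound 2 and no change at the digits printed (within the scatter) from compound 4 to compound 3, 4 percentage points apart, within the scatter of two such steps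

The compounds shown leave open whether the higher numbers of compound 3 and compound 4 over compound 1 and compound 2 belong to the group on the amide nitrogen, since those pairs differ in more than one place and no single-change step can be read from them. Also open, from the compounds shown here alone, is whether a larger group at this carbon, such as methoxy or a dimethylamino group, would lower the read-out, and whether the core of compound 4 would hold it with hydrogen in place of the remaining fluoro.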